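A few compounds are considered here, and "the series" means these few. Any claim that something is new, unique, unknown or untested is made for them only; others in the source may bear on it.

Compound 1, `N=c1oc2ccc(Br)cc2cc1C(=O)NCCO`, gives 26% in an assay on CHO cells for displacement of a labelled ligand from adenosine receptor A1 (Homo sapiens), read by scintillation counting, with a stated time of 60 min, tested at 10 uM; a lower number here means less inhibition, a higher number more inhibition at the concentration tested (going by the name of the read-out).
Compound 2, `COc1cccc2cc(C(=O)NCCO)c(=N)oc12`, gives 47% in this assay.
Compound 3, `COc1cccc2cc(C(=O)NC3CCCC3)c(=N)oc12`, gives > 70% in this assay, which is a limit of the assay and not a number.

Compound 3 therefore sits at the limit of > 70% in this assay, at which 1 of the 3 values shown sits, so its true inhibition is known only as lying beyond that bound. Among the compounds with values here, the one measured step that bears on the present change is a number at least 23 percentage points higher from compound 2 to compound 3 (beyond the scatter), a rise that came from putting cyclopentyl in place of 2-hydroxyethyl on the amide-type nitrogen.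

Compound 4, `COc1cccc2cc(C(=O)NC(CO)(CO)CO)c(=N)oc12`, differs from compound 3 in 2-hydroxy-1,1-bis(hydroxymethyl)ethyl in place of cyclopentyl on an amide-type nitrogen. This undoes the cyclopentyl of compound 3 and puts in its place a group of the same kind as the 2-hydroxyethyl of compound 2, but with three hydroxyls rather than one. A fall in this assay is expected because a number at least 23 percentage points higher from compound 2 to compound 3 (beyond the scatter) was the rise seen in the other direction. Compound 4 is thus expected to give about 32%, within 12% to 55%. That estimate means an expected step of a number at least 38 percentage points lower from compound 3 to compound 4 (beyond the scatter).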

Compound 4, a percentage reported as inhibition, at one concentration (the size of the read-out at that concentration, not a potency): 19%
Beside the measured number, compound 4's estimate is 13 percentage points above it; low and high end bracket the measured number.
By their numbers in this assay, from the lowest: compounds 4 and 1 (each within the scatter of the next); then compound 2. At a limit, above all of these: compound 3.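

In this assay, putting 2-hydroxy-1,1-bis(hydroxymethyl)ethyl in place of cyclopentyl on the amide-type nitrogen gives a number at least 51 percentage points lower from compound 3 to compound 4 (beyond the scatter), the largest step yet seen at this position. The same group in place of 2-hydroxyethyl gives a number 28 percentage points lower from compound 2 to compound 4 (beyond the scatter), so more hydroxyls on this nitrogen take the inhibition past the level of the single-hydroxyl chain rather than simply back to it. The full size of the fall from cyclopentyl stays unknown, as compound 3 stands at a limit of the assay: the limit of > 70% in this assay, at which 1 of the 4 values shown sits.

The compounds shown leave open whether a 2,3-dihydroxypropyl chain, an amine or a carboxylic acid on this nitrogen would fall nearer compound 2 or compound 4. They also leave open whether a cyclohexyl ring or an open pentyl chain would keep the inhibition of compound 3.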